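This account rests on a few compounds, and the source may have more. Where it says the series, first, only, none or still open, it means among the compounds named here.

Measured in a functional assay on MDA-MB-231 cells (Homo sapiens) for inhibition, read by CCK-8 assay, with a stated time of 48 h; on this read-out higher numbers stand for weaker inhibition of growth and lower numbers for stronger inhibition of growth:
- compound 1 `Cc1ccc(CNc2nc(Nc3ccc(N4CCN(C)CC4)cn3)ncc2Cl)cc1`: 18600 nM
- compound 2 `CN1CCN(c2ccc(Nc3ncc(Cl)c(NCc4ccc(F)cc4)n3)nc2)CC1`: > 100000 nM (a limit, not a number)
- compound 3 `COc1ccccc1CNc1nc(Nc2ccc(N3CCN(C)CC3)cn2)ncc1Cl`: 29300 nM

Compound 3 gives 29300 nM. For the measured compounds named here, the one step between two actual numbers is a 1.6-fold higher number from compound 1 to compound 3 (0.20 log units; within the scatter), so these two values cannot be ranked. The steps that involve the limit are an at least 5.3-fold higher number from compound 1 to compound 2 (0.73 log units; beyond the scatter) and an at least 3.4-fold lower number from compound 2 to compound 3 (0.53 log units; beyond the scatter).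

Compound 4 `Cc1ccc(Nc2nc(Nc3ccc(N4CCN(C)CC4)cn3)ncc2Cl)cc1` has 4-methylphenyl in place of 2-methoxybenzyl on a nitrogen on an aromatic ring. Going by the values given here, no measured step makes this kind of change, since all three exchange one aryl group for another on a saturated chain carbon. The closest guide is compound 1 at 18600 nM, which carries the same 4-methylphenyl on such a chain carbon. With a 1.6-fold higher number from compound 1 to compound 3 (0.20 log units; within the scatter) as the reference, no shift beyond the scatter is expected in this assay, although an at least 5.3-fold higher number from compound 1 to compound 2 (0.73 log units; beyond the scatter) argues for a wide range. The expected step is a 1.5-fold lower number from compound 3 to compound 4 (0.17 log units; within the scatter). Compound 4 is estimated at 20000 nM, with an expected range from 5000 nM to 80000 nM. A reported limit stays possible, given (the limit of > 100000 nM in this assay, at which 1 of the 3 values shown sits).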

Compound 4, concentration for 50% growth inhibition: 4030 nM
Compound 4: the middle estimate sits 5.0-fold (0.70 log units) above what was measured; measured number outside the range, below it.
By their numbers in this assay, from the lowest: compound 4; then compounds 1 and 3 (each within the scatter of the next). At a limit, above all of these: compound 2.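

In this assay, for the compounds shown here, the step of a 4.6-fold lower number from compound 1 to compound 4 (0.66 log units; beyond the scatter) is the first between two actual numbers to lie beyond the scatter, and it comes from 4-methylphenyl in place of 4-methylbenzyl on a nitrogen on an aromatic ring, a change of a different kind from the earlier aryl exchanges on the saturated chain carbon. The step of a 7.3-fold lower number from compound 3 to compound 4 (0.86 log units; beyond the scatter) points the same way and is also beyond the scatter, so among the compounds shown, each of those with an aryl group on a saturated chain carbon gives a higher number than compound 4, with none going against this. Compound 2 remains a limit and not a number, so the step of an at least 24-fold lower number from compound 2 to compound 4 (1.39 log units; beyond the scatter) gives only a minimum size for that change: the limit of > 100000 nM in this assay, at which 1 of the 4 values shown sits.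

With compound 4 the only one of its kind, the compounds shown do not separate the effect of the 4-methylphenyl group itself from that of the shorter link to the nitrogen. As far as these compounds go, it also remains open how 4-fluorophenyl, 2-methoxyphenyl, an unsubstituted phenyl or a longer chain such as 2-phenylethyl would read on that nitrogen.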